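Cyclopentyl to Methyl on the Shared Core

The compounds below may be only part of what the source reports. "The series", "measured", "known", "first", "only" and "open" are said of these compounds alone.

Measured compounds:
Compound 1 `COc1cc(-c2cnn3cc(OC)c(C4CCCC4)nc23)ccn1`: 7%
Compound 2 `Cn1cc(-c2nc3c(-c4ccnc(OC5CC5)c4)cnn3cc2OCCCC(C)(C)O)cn1`: 64%

In an ADME assay on microsomes from liver (Rattus norvegicus) for metabolic stability, with a stated time of 60 min, tested at 1 uM (a higher number here means that more of the compound is left, a lower number that less of the compound is left), compound 1 gives 7%, the lowest of the two numbers, with compound 2 giving 64%, a value beyond the scatter. Compound 3 `COc1cc(-c2cnn3cc(OC)c(C)nc23)ccn1` is not yet measured. It differs from compound 1 in one place: methyl in place of cyclopentyl on an aromatic carbon. Among the compounds with values here, no step between measured compounds covers this change, so the expectation rests on compound 1 alone; a moderate rise in this assay is estimated, giving a number 15 percentage points higher from compound 1 to compound 3 (beyond the scatter). Compound 3 is expected to show 22%, within 6% to 45%.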

Compound 3, percent of the compound remaining: 13%
For compound 3 the middle estimate is 9 percentage points above the measured one; the measured number falls inside the stated range.
By their numbers in this assay, from the lowest: compounds 1 and 3 (each within the scatter of the next); then compound 2.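

In this assay the change from cyclopentyl to methyl on this aromatic carbon gives a number 6 percentage points higher from compound 1 to compound 3 (within the scatter) and so does not separate the two compounds. At this position, then, trading the five-membered carbon ring for a single carbon leaves the read-out unmoved beyond the usual scatter. The data offer no measured basis for explaining this result. As far as these compounds go, whether an amine, a carboxylic acid or a longer chain ending in a hydroxyl group on this carbon would leave more of the compound remains open.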